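This account rests on a few compounds, and the source may have more. Where it says the series, first, only, none or still open, it means among the compounds named here.

Compound 3, `COc1c(F)cccc1C1CCN(c2ccn3c(CC4CC4)nnc3c2Cl)CC1`, is one of three compounds that share a core and differ only in the fluoro pattern of the phenyl group held on a saturated ring carbon. In a functional assay on CHO cells for agonist activity at metabotropic glutamate receptor 2 (Homo sapiens), read by scintillation counting and GTPgammaS binding, with a stated time of 30 min (on this read-out lower numbers stand for smaller maximal responses and higher numbers for larger maximal responses), compound 3 gives 336%, the second highest of the three numbers. Compound 1, `COc1ccccc1C1CCN(c2ccn3c(CC4CC4)nnc3c2Cl)CC1`, gives 345% in this assay, and the step of a number 9 percentage points lower from compound 1 to compound 3 (within the scatter) stays within the scatter, so the two read the same. Compound 2, `COc1cccc(F)c1C1CCN(c2ccn3c(CC4CC4)nnc3c2Cl)CC1`, gives 304% in this assay, and the step of a number 32 percentage points higher from compound 2 to compound 3 (beyond the scatter) lies beyond the scatter.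

Compound 4, `COc1c(C2CCN(c3ccn4c(CC5CC5)nnc4c3Cl)CC2)ccc(F)c1F`, carries a second fluoro group: fluoro in place of hydrogen on an aromatic carbon, so that the 3-fluoro-2-methoxyphenyl becomes a 3,4-difluoro-2-methoxyphenyl. Two measured steps show the same kind of change. The step of a number 41 percentage points lower from compound 1 to compound 2 (beyond the scatter) is large, whereas the step of a number 9 percentage points lower from compound 1 to compound 3 (within the scatter) is not. So adding one fluoro group has ranged from no effect to a clear drop, and a drop toward the lower end of this range, or none beyond the scatter, is the expected outcome. The estimated step is a number 24 percentage points lower from compound 3 to compound 4 (beyond the scatter). Compound 4 is therefore expected to give about 312%, within a range from 270% to 350%.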

Compound 4, largest response reached (Emax), in percent of the reference or control that the assay uses: 342%
For compound 4 the middle estimate is 30 percentage points below the measured one, within the range that was stated.
By their numbers in this assay, from the lowest: compound 2; then compounds 3, 4 and 1 (each within the scatter of the next).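

With a fluoro group ortho to the first one and para to a large group, the maximal response holds steady, with the step being a number 6 percentage points higher from compound 3 to compound 4 (within the scatter) and the comparison with the parent without fluoro being a number 3 percentage points lower from compound 1 to compound 4 (within the scatter) on the same read-out. This position therefore accepts a second fluoro group in this assay without a measurable loss, and compound 2 remains the one that stands apart, as the step to the difluoro compound is a number 38 percentage points higher from compound 2 to compound 4 (beyond the scatter) and so is clearly large. Replacing hydrogen with fluoro on the aromatic ring thus has no single size of effect in this small set, and its outcome depends on the phenyl pattern it enters: the same change on two cores in this assay, a number 41 percentage points lower (beyond the scatter) from compound 1 to compound 2 and a number 6 percentage points higher (within the scatter) from compound 3 to compound 4, 47 percentage points apart, beyond the scatter of two such steps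

These compounds leave open whether the position would accept anything larger than fluoro, such as a methyl group, a nitrile or a carboxylic acid, since hydrogen and fluoro are the only groups shown there. They also leave open whether the response would hold if the methoxy group were replaced by a longer chain such as propoxy while the 3,4-difluoro pattern stayed in place.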